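Changing the Amide Substituent: Expected Agonist Efficacy

This account rests on a few compounds, and the source may have more. Where it says the series, first, only, none or still open, it means among the compounds named here.

Among the compounds with values here, compound 1 `CSc1cccc(NC(=O)CN2CCC(c3cccc[n+]3[O-])CC2)c1` stands lower of the two compounds measured so far: in a functional assay on HEK293 cells for agonist activity at D(4) dopamine receptor (Homo sapiens), read by FLIPR (on this read-out higher numbers stand for larger maximal responses and lower numbers for smaller maximal responses), compound 1 gives 56%, whereas compound 2 `O=C(CN1CCC(c2cccc[n+]2[O-])CC1)Nc1cccc(C(F)(F)F)c1` gives 75%. Within the data shown here, the single measured step, a number 19 percentage points higher from compound 1 to compound 2 (beyond the scatter), comes from trifluoromethyl in place of methylsulfanyl on an aromatic carbon. Compound 3 `Cc1ccc(Cl)cc1NC(=O)CN1CCC(c2cccc[n+]2[O-])CC1` differs from compound 1 in a different way: 5-chloro-2-methylphenyl in place of 3-(methylsulfanyl)phenyl on an amide-type nitrogen. Among the measured compounds shown here, the one measured step does not cover this change, so it offers little direct guidance; it only shows that altering the group on the amide-type nitrogen can move efficacy beyond the scatter, here upward. Given this, the step expected for compound 3 is a number 4 percentage points higher from compound 1 to compound 3 (within the scatter), with no confident direction. Compound 3 is therefore estimated to give 60% in this assay, with a likely range from 35% to 85%.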

Compound 3, largest response reached (reported as efficacy), in percent of the reference or control that the assay uses: 58%
For compound 3 the middle estimate is 2 percentage points above the measured one, within the range that was stated.
By their numbers in this assay, from the lowest: compounds 1 and 3 (each within the scatter of the next); then compound 2.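

In this assay, 5-chloro-2-methylphenyl in place of 3-(methylsulfanyl)phenyl on the amide-type nitrogen gives a number 2 percentage points higher from compound 1 to compound 3 (within the scatter). This shows that not every change on this nitrogen shifts the maximal response beyond the usual scatter, and that an aromatic group with chlorine and methyl and no sulfur can sit here with a response that matches that of compound 1 within the scatter. No independent measurement is available to explain why these two different groups give matching responses.

Because the entering group carries two substituents, the compounds shown cannot tell what chlorine or methyl contributes on its own, so a phenyl ring bearing only one of them would separate the two. From the compounds shown here alone, it also remains open how the response would change with an amine or a carboxylic acid on the ring.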